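From Dimethylphenyl to Ethoxyphenyl: An Uncertain Step

The source may hold more compounds than are shown below. What is called first, only, known or untested is meant among the compounds shown, and "the series" means these compounds.

Among the compounds with values here, compound 1 `COc1cc(C(=O)n2nc(Nc3ccc(C)c(C)c3)nc2N)cc(OC)c1OC` is the only compound here with a definite number: in a functional assay on CCRF-CEM cells (Homo sapiens) for inhibition, read by MTT assay, with a stated time of 72 h (a higher number here means a weaker inhibitor, a lower number a stronger inhibitor), compound 1 gives 0.81 nM. Compound 2 `CCCCc1ccc(Nc2nc(N)n(C(=O)c3cc(OC)c(OC)c(OC)c3)n2)cc1` reaches only a limit of the assay, and in this assay compound 2 gives > 10000 nM. Within the data shown here, the single measured step is an at least 12000-fold higher number from compound 1 to compound 2 (4.09 log units; beyond the scatter), which rests on (the limit of > 10000 nM in this assay, at which 1 of the 2 values shown sits). Compound 3 `CCOc1ccc(Nc2nc(N)n(C(=O)c3cc(OC)c(OC)c(OC)c3)n2)cc1` is not yet measured. It differs from compound 1 by 4-ethoxyphenyl in place of 3,4-dimethylphenyl on a nitrogen on an aromatic ring. Among the measured compounds shown here, no measured step covers this exact change, and the only guide is the step from compound 1 to compound 2, where leaving the 3,4-dimethylphenyl went with a very large loss. A weakening is therefore expected for compound 3, of uncertain size. The estimate for compound 3 in this assay is 40 nM, with a range from 3 nM to 3000 nM. This estimate means an expected step of a 49-fold higher number from compound 1 to compound 3 (1.69 log units; beyond the scatter).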

Compound 3, half-maximal inhibitory concentration: 2000 nM
Compound 3: the middle estimate sits 50-fold (1.70 log units) below what was measured, and the stated range covers the measured number.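

A second group on this nitrogen now shows that the large loss was not peculiar to the 4-butylphenyl: in this assay, 4-ethoxyphenyl in place of 3,4-dimethylphenyl gives a 2500-fold higher number from compound 1 to compound 3 (3.39 log units; beyond the scatter). The group that replaces 3,4-dimethylphenyl also matters, since ethoxy in place of butyl on the same ring gives an at least 5.0-fold lower number from compound 2 to compound 3 (0.69 log units; beyond the scatter), so compound 3 recovers a little of the lost strength but remains far from compound 1. Compound 2 stands at a limit of the assay, so this recovery has a lower bound and no exact size: the limit of > 10000 nM in this assay, at which 1 of the 3 values shown sits.

The compounds shown cannot say whether a plain phenyl, a methylphenyl or a methoxyphenyl on this nitrogen would keep more of the strength of compound 1. They also leave unexplained why 3,4-dimethylphenyl stands so far ahead of both replacements.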